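Swapping a propyl-bearing ring for an amino-bearing one

This account rests on a few compounds, and the source may have more. Where it says the series, first, only, none or still open, it means among the compounds named here.

Of the compounds shown here, three sharing one core have been tested in an assay on isolated protein for inhibition of Rho-associated protein kinase 2 (Homo sapiens), read by scintillation counting, radiometric assay and 33P incorporation, with a stated time of 40 min, in the presence of a further agent that is not named here; a higher number here means a weaker inhibitor, a lower number a stronger inhibitor. Compound 1, `Cc1c(OCC(=O)Nc2cccc(NC(=O)c3ccc(N(C)C)cc3)c2)ccc2c(=O)ccoc12`, gives 4160 nM. Compound 2, `CCCc1ccc(C(=O)Nc2cccc(NC(=O)COc3ccc4c(=O)ccoc4c3)c2)cc1`, gives 14 nM. Compound 3, `O=C(COc1ccc2c(=O)ccoc2c1)Nc1cccc(NS(=O)(=O)c2ccc(C(F)(F)F)cc2)c1`, gives 6890 nM. Compound 2 thus gives the lowest of the three numbers and is the strongest inhibitor of the set, since its gaps to compound 1 and to compound 3 both lie well beyond the scatter; compound 1 is the nearer of the two, compound 3 the further.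

Compound 4, `Nc1cccc(C(=O)Nc2cccc(NC(=O)COc3ccc4c(=O)ccoc4c3)c2)c1`, has not yet been measured. It differs from compound 2 in one place: 3-aminophenyl in place of 4-propylphenyl on a carbonyl carbon. No single-change comparison among the measured compounds speaks directly to this swap. Still, the two other measured compounds, which carry other groups on this part of the molecule, are both far weaker, so compound 4 is expected to lose potency, with an estimated step of an 18-fold higher number from compound 2 to compound 4 (1.25 log units; beyond the scatter) in this assay . Compound 4 is estimated to give about 250 nM, with a likely range from 40 nM to 1500 nM.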

Compound 4, half-maximal inhibitory concentration: 58 nM
The estimate for compound 4 lay 4.3-fold (0.63 log units) above the measured number; the range from low to high includes it.
By their numbers in this assay, from the lowest: compound 2; then compound 4; then compounds 1 and 3 (each within the scatter of the next).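

In this assay, the step of a 4.1-fold higher number from compound 2 to compound 4 (0.62 log units; beyond the scatter) is beyond the scatter but modest. Within the data shown here, the 4-propylphenyl group is therefore not the only group on this carbonyl carbon that keeps inhibition strong: compound 4, whose 3-aminophenyl group has fewer heavy atoms and adds a hydrogen-bond donor and acceptor, gives 58 nM and loses only part of the potency of compound 2. Nothing available explains why the step has this size.

The swap changes both the group and its printed ring number, so these compounds cannot separate the two effects. A 4-aminophenyl or 3-propylphenyl group on the same carbonyl carbon would separate them, and a plain phenyl would show what either group adds.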